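The source may report more compounds than this note shows. Statements on the series, on what has been measured and on what is new or still open speak of the compounds shown alone.

Compound 1 `COc1nc2ccc(Br)cc2cc1C(c1ccccc1)n1cc(-c2ccccc2F)nn1` is measured in an ADME assay on HEK293 cells (Homo sapiens) for cytotoxicity, read by sulforhodamine B assay, with a stated time of 48 h, tested at 10 uM (a higher number here means more inhibition at the concentration tested (going by the name of the read-out), a lower number less inhibition), where compound 1 gives 3.97%. Two analogues differ from it only in the group on an aromatic carbon: compound 2 `CCCc1cn(C(c2ccccc2)c2cc3cc(Br)ccc3nc2OC)nn1` gives 0.85% in this assay, and compound 3 `COc1nc2ccc(Br)cc2cc1C(c1ccccc1)n1cc(-c2cccc(F)c2)nn1` gives 6.84%. Compound 1 lies within the scatter of both neighbours, with a number 3.1 percentage points lower from compound 1 to compound 2 (within the scatter) and a number 2.9 percentage points higher from compound 1 to compound 3 (within the scatter); the step of a number 6 percentage points higher from compound 2 to compound 3 (within the scatter) also stays within the scatter. Compound 4 `COc1nc2ccc(Br)cc2cc1C(c1ccccc1)n1cc(-c2ccc(F)cc2)nn1` differs from compound 1 by 4-fluorophenyl in place of 2-fluorophenyl on an aromatic carbon. Among the measured compounds shown here, the step of a number 2.9 percentage points higher from compound 1 to compound 3 (within the scatter) bears most directly on this change, and since no step among the three measured compounds exceeds the scatter, no shift beyond the scatter is expected in this assay. Compound 4 is therefore estimated at 5%, range 0% to 14%, an expected step of a number 1 percentage points higher from compound 1 to compound 4 (within the scatter).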

Compound 4, a percentage reported as inhibition, at one concentration (the size of the read-out at that concentration, not a potency): 4.04%
Compound 4: the middle estimate sits 1 percentage points above what was measured; low and high end bracket the measured number.
By their numbers in this assay, from the lowest: compounds 2, 1, 4 and 3 (each within the scatter of the next).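

Compounds with 2-fluorophenyl, 3-fluorophenyl and 4-fluorophenyl on this aromatic carbon cannot be told apart in this assay, with a number 0.1 percentage points higher from compound 1 to compound 4 (within the scatter) and a number 2.8 percentage points lower from compound 3 to compound 4 (within the scatter). The 4-fluorophenyl group also does not separate from propyl, with a number 3.2 percentage points higher from compound 2 to compound 4 (within the scatter). No evidence is available to explain these readings.

From the compounds shown here alone, whether any group at this carbon can move the number beyond the scatter remains open. An amine or a carboxylic acid on the phenyl ring, or a longer chain in place of propyl, would test this.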